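Growing the ring on the shared core: from cyclopropyl to cyclobutyl

The compounds below may be only part of what the source reports. "The series", "measured", "known", "first", "only" and "open" are said of these compounds alone.

Two compounds built on one core differ only in the small group on an aromatic carbon. Compound 1 `CCCCOC(=O)NS(=O)(=O)c1ccc(CCC)cc1-c1ccc(Cn2c(CC)nc3ccccc32)cc1` carries an ethyl group there, and compound 2 `CCCCOC(=O)NS(=O)(=O)c1ccc(CCC)cc1-c1ccc(Cn2c(C3CC3)nc3ccccc32)cc1` a cyclopropyl. In an assay on membranes from HEK293 cells for displacement of a labelled ligand from Type-2 angiotensin II receptor (Homo sapiens), read by radioligand binding (on this read-out higher numbers stand for weaker inhibition and lower numbers for stronger inhibition), compound 1 gives 11 nM. In this assay compound 2 gives 31 nM, which is a 2.8-fold higher number from compound 1 to compound 2 (0.45 log units; beyond the scatter). Among the compounds with values here, of the two numbers measured so far, compound 2 therefore has the higher one, meaning the weaker inhibition, and it stands apart from compound 1 by more than the usual scatter.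

Compound 3 `CCCCOC(=O)NS(=O)(=O)c1ccc(CCC)cc1-c1ccc(Cn2c(C3CCC3)nc3ccccc32)cc1` takes this one step further. Its change from compound 2 is cyclobutyl in place of cyclopropyl on an aromatic carbon. Within the data shown here, only the single step from compound 1 to compound 2 bears on what to expect, and that step made the ring-bearing compound modestly weaker. Continuing from a three-membered to a four-membered ring, compound 3 is expected to show a 1.6-fold higher number from compound 2 to compound 3 (0.21 log units; within the scatter), a small shift toward weaker inhibition that may or may not exceed the scatter. The estimate for compound 3 in this assay is 50 nM, with a range from 20 nM to 130 nM.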

Compound 3, inhibition constant: 12 nM
The estimate for compound 3 lay 4.2-fold (0.62 log units) above the measured number; the measured number lies below the stated range.
By their numbers in this assay, from the lowest: compounds 1 and 3 (each within the scatter of the next); then compound 2.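

The change from cyclopropyl to cyclobutyl gives a 2.6-fold lower number from compound 2 to compound 3 (0.41 log units; beyond the scatter) in this assay, so on this aromatic carbon between two ring nitrogen atoms, the earlier step from ethyl to cyclopropyl does not extend into a steady trend as the ring grows. The comparison with the open-chain group gives a 1.1-fold higher number from compound 1 to compound 3 (0.04 log units; within the scatter) and shows that a non-aromatic carbon ring at this position does not by itself bring weaker inhibition: of the three compounds, only compound 2, with its three-membered ring, stands apart from the other two by more than the scatter. The data offer no measurement that explains why the three-membered ring behaves differently from the four-membered ring.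

The compounds shown leave open how the number responds when the ring grows further, to cyclopentyl or cyclohexyl, and whether a longer chain such as propyl or butyl would match ethyl here. They also leave open what happens when a ring carbon is replaced by oxygen or nitrogen, as in oxetanyl or azetidinyl, at this same position.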